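Fluoro in place of 1H-1,2,3-triazol-4-yl: compound 4

A few compounds are considered here, and "the series" means these few. Any claim that something is new, unique, unknown or untested is made for them only; others in the source may bear on it.

Measured in an ADME assay on microsomes from liver (Canis lupus familiaris) for metabolic stability, read by LC-MS, using NADPH, with a stated time of 10 min, tested at 0.1 uM; on this read-out higher numbers stand for fast clearance and lower numbers for slow clearance:
compound 1 `C#Cc1cc(C(=O)NCCCCc2ccccc2)cc(C2SCC(=O)N2c2ccccc2OC)c1`: 1750 mL.min-1.g-1
compound 2 `Cc1cccc(N2C(=O)CSC2c2cccc(C(=O)NCCCCc3ccccc3)c2)c1`: 749 mL.min-1.g-1
compound 3 `O=C(NCCCCc1ccccc1)c1cccc(C2SCC(=O)N2c2cccc(-c3c[nH]nn3)c2)c1`: 226 mL.min-1.g-1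

Of these three, compound 3 has the lowest number, 226 mL.min-1.g-1, and its gaps to compound 1 and compound 2 lie beyond the scatter. Compound 4 `O=C(NCCCCc1ccccc1)c1cccc(C2SCC(=O)N2c2cccc(F)c2)c1` is not yet measured. It differs from compound 3 in one place: fluoro in place of 1H-1,2,3-triazol-4-yl on an aromatic carbon. The fluoro sits on an aromatic carbon, meta to a large group. Within the data shown here, one measured step bears on this: a 3.3-fold lower number from compound 2 to compound 3 (0.52 log units; beyond the scatter), where 1H-1,2,3-triazol-4-yl entered in place of methyl. Among the measured compounds shown here, no measured compound carries fluoro, so the estimate rests on that single step. Losing 1H-1,2,3-triazol-4-yl is therefore expected to reverse a step of similar size in this assay. The expected change is a 2.7-fold higher number from compound 3 to compound 4 (0.42 log units; beyond the scatter), a rise in the number. For compound 4 the estimated value is 600 mL.min-1.g-1, with an expected range of 280 mL.min-1.g-1 to 1250 mL.min-1.g-1.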

Compound 4, intrinsic clearance in microsomes: 837 mL.min-1.g-1
For compound 4 the middle estimate is 1.4-fold (0.14 log units) below the measured one; the measured number falls inside the stated range.
By their numbers in this assay, from the lowest: compound 3; then compounds 2 and 4 (each within the scatter of the next); then compound 1.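

In this assay the step of a 3.7-fold higher number from compound 3 to compound 4 (0.57 log units; beyond the scatter) shows that fluoro, like methyl, gives a clearly higher number than 1H-1,2,3-triazol-4-yl on this aromatic carbon. The step of a 1.1-fold higher number from compound 2 to compound 4 (0.05 log units; within the scatter) leaves fluoro and methyl indistinguishable here, so among these three groups only 1H-1,2,3-triazol-4-yl stands apart. The compounds shown offer no measurement that accounts for this difference. Open, on these data alone, is whether an amine or a carboxylic acid on this carbon would give a number like that of compound 3. Also open, as far as these compounds go, is whether another five-membered aromatic ring, such as a tetrazole, would do the same.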